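From Compound 3 to Compound 4: One Side-Group Exchange

The compounds below may be only part of what the source reports. "The series", "measured", "known", "first", "only" and "open" are said of these compounds alone.

Of the compounds shown here, three have been measured in an assay for displacement of a labelled ligand from E3 ubiquitin-protein ligase Mdm2 (Homo sapiens), read by fluorescence polarization, with a stated time of 30 min; on this read-out higher numbers stand for weaker inhibition and lower numbers for stronger inhibition. Compound 1 `CC(C)COc1ccc(-c2cc(C(=O)O)nn2-c2ccccc2)cc1` gives 7420 nM, compound 2 `CC(C)Oc1ccc(-c2cc(C(=O)O)nn2-c2ccc(Oc3ccccc3)cc2)cc1` gives 712 nM, and compound 3 `CCOc1ccc(-c2c(NC(=O)c3ccc(C(C)(C)C)cc3)c(C(=O)O)nn2-c2ccc(Oc3ccccc3)cc2)cc1` gives 689 nM. Compound 3 thus carries the lowest number of the three, yet its value and that of compound 2 lie within the usual scatter, so no order can be read between them; only compound 1 stands clearly apart with its higher number. Compound 4 `CCOc1ccc(-c2c(NC(=O)c3ccc(OCC(C)C)cc3)c(C(=O)O)nn2-c2ccc(Oc3ccccc3)cc2)cc1` differs from compound 3 in one place: isobutoxy in place of tert-butyl on an aromatic carbon. For the measured compounds named here, no measured pair shows this exchange, so there is no step to lean on. The expected step of a 1.0-fold higher number from compound 3 to compound 4 (0.01 log units; within the scatter) is small, none beyond the scatter. In this assay compound 4 is estimated at 700 nM, with a range from 250 nM to 2000 nM.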

Compound 4, inhibition constant: 446 nM
Compound 4: middle estimate off by 1.6-fold (0.20 log units), on the high side; low and high end bracket the measured number.
By their numbers in this assay, from the lowest: compounds 4, 3 and 2 (each within the scatter of the next); then compound 1.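

In this assay, putting isobutoxy in place of tert-butyl, para to a large group, gives a 1.5-fold lower number from compound 3 to compound 4 (0.19 log units; within the scatter) and so leaves the read-out unresolved between the two groups. This position therefore accepts a chain carrying an oxygen as well as a compact all-carbon group, at least for this one pair. Nothing available here offers an explanation for this result.

On these data alone, whether an amine, a carboxylic acid or a longer chain at this position would also read alike remains open. A single exchange also cannot show how far this tolerance extends.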